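This account rests on a few compounds, and the source may have more. Where it says the series, first, only, none or still open, it means among the compounds named here.

Measured compounds in the series:

Compound 1, `COC(=O)c1ccc(NCc2cncn2Cc2ccccc2N)cc1-c1ccccc1`. In a toxicity assay on NIH3T3 cells (Mus musculus) for cytotoxicity, read by resazurin assay (a lower number here means that less compound is needed, a higher number that more compound is needed for the effect), compound 1 gives 25000 nM.
Compound 2, `CCOC(=O)c1ccc(NCc2cncn2Cc2ccc(-c3ccccc3)cc2)cc1-c1ccccc1`. Compound 2 reaches only the limit of the assay, > 10000 nM, and no single number.
Compound 3, `COC(=O)c1ccc(NCc2cncn2Cc2ccc(C(C)(C)C)cc2)cc1-c1ccccc1`. For compound 3 the result is "not determined" (no result reported).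

Compound 2 therefore stands at the limit of > 10000 nM in this assay, at which 1 of the 3 values shown sits. Going by the values given here, of the three entries only compound 1 carries a number; compound 2 sits at the limit and compound 3 has no reading, so no step between measured compounds can be drawn and nothing here shows whether the change at the ester end moves the read-out at all.

Compound 4, `c1ccc(-c2ccc(Cn3cncc3CNc3ccc(-c4ccc[nH]4)c(-c4ccccc4)c3)cc2)cc1`, is the next one to be measured. The change from compound 2 is 1H-pyrrol-2-yl in place of ethoxycarbonyl on an aromatic carbon. Among the compounds with values here, with no measured step to lean on, the expectation is for no shift beyond the scatter: compound 2 to compound 4 is estimated as a step that the limit leaves unreadable from compound 2 to compound 4. Compound 4 is expected near 15000 nM, within 4000 nM to 50000 nM, and a report of only a limit, as for compound 2, is as likely as a number.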

Compound 4, half-maximal effective concentration: > 10000 nM
Compound 4: no number, only a limit; the forecaster's own chance of this, stated with the estimate: 50%; the middle value is on the limit's open side.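

No step can be read between compound 2 and compound 4: both carry only a limit in this assay. For compound 4 that limit is > 10000 nM, which is not a number. The compounds shown leave open whether 1H-pyrrol-2-yl in place of ethoxycarbonyl on the aromatic carbon shifts the read-out at all.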